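The source may hold more compounds than are shown below. What is called first, only, known or untested is meant among the compounds shown, and "the series" means these compounds.

Measured compounds:
- Compound 1, `COc1cccc(S(=O)(=O)Nc2ccc3oc(-c4ccccc4)nc3c2)c1`: in an assay on cells for inhibition of HSP60/HSP10 (Homo sapiens), with a stated time of 60 min (a lower number here means a stronger inhibitor, a higher number a weaker inhibitor), compound 1 gives > 100000 nM, a limit of the assay rather than a number.
- Compound 2, `O=S(=O)(Nc1ccc2oc(-c3ccccc3)nc2c1)c1ccc(Cl)cc1`: in this assay compound 2 gives > 100000 nM, again a limit.
- Compound 3, `O=S(=O)(Nc1ccc2oc(-c3ccccc3)nc2c1)c1cccc(O)c1`: in this assay compound 3 gives 76000 nM.

Going by the values given here, compound 3 therefore holds the only numerical value; the other two sit at the limit of > 100000 nM in this assay, at which 2 of the 3 values shown sit. Compound 4, `O=S(=O)(Nc1ccc2oc(-c3ccccc3)nc2c1)c1ccccc1O`, is not yet measured. It differs from compound 3 by 2-hydroxyphenyl in place of 3-hydroxyphenyl on a sulfonyl sulfur. Among the compounds with values here, the steps that bear on this are an at least 1.3-fold lower number from compound 1 to compound 3 (0.11 log units; that floor lies within the scatter) and an at least 1.3-fold lower number from compound 2 to compound 3 (0.11 log units; that floor lies within the scatter); both are floors that lie within the scatter, so the hydroxyphenyl series gives no readable size. Moving the hydroxyl within the same ring is expected to produce no step beyond the scatter. Compound 4 is expected at 76000 nM (range 25000 nM to 200000 nM). That estimate means no change at the digits printed from compound 3 to compound 4 (within the scatter).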

Compound 4, half-maximal inhibitory concentration: 85000 nM
Compound 4: middle estimate off by 1.1-fold (0.05 log units), on the low side, within the range that was stated.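

In this assay, 2-hydroxyphenyl and 3-hydroxyphenyl on the sulfonyl sulfur cannot be told apart: a 1.1-fold higher number from compound 3 to compound 4 (0.05 log units; within the scatter). Compound 4 also gives two further steps that are only floors, an at least 1.1-fold lower number from compound 2 to compound 4 (0.07 log units; that floor lies within the scatter) and an at least 1.1-fold lower number from compound 1 to compound 4 (0.07 log units; that floor lies within the scatter). The true size of both stays unreadable because compound 1 and compound 2 sit at a limit: the limit of > 100000 nM in this assay, at which 2 of the 4 values shown sit.

Still open, as far as these compounds go, is whether an amine or a carboxylic acid in place of the hydroxyl on this ring would give a step beyond the scatter. The shared core is also untested by these compounds, since all of them keep it unchanged.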